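The source may report more compounds than this note shows. Statements on the series, on what has been measured and on what is new or still open speak of the compounds shown alone.

Measured in an ADME assay on HepG2 cells (Homo sapiens) for cytotoxicity, read by MTT assay, with a stated time of 72 h; on this read-out lower numbers stand for higher toxicity in this test and higher numbers for lower toxicity in this test:
Compound 1 `CC(C)(C)Nc1nc2cc(-c3ccccc3)sc2c(=O)[nH]1`: 12500 nM
Compound 2 `CC(C)(C)Nc1nc2ccsc2c(=O)[nH]1`: 8400 nM
Compound 3 `CC(C)Nc1nc2ccsc2c(=O)[nH]1`: 23900 nM

Compound 2 stands at the low end of these numbers, within the scatter of compound 1. The other measured step, a 2.8-fold higher number from compound 2 to compound 3 (0.45 log units; beyond the scatter), concerns the chain on the nitrogen and does not bear here.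

Compound 4 `CC(C)(C)Nc1nc2c(-c3ccc(F)cc3)csc2c(=O)[nH]1` has 4-fluorophenyl in place of hydrogen on an aromatic carbon of compound 2: 4-fluorophenyl in place of hydrogen on an aromatic carbon. The nearest guide is a 1.5-fold lower number from compound 1 to compound 2 (0.17 log units; within the scatter), which removes a phenyl, though from another carbon. Within the data shown here, no measured compound carries 4-fluorophenyl. No step beyond the scatter is therefore expected in this assay, in either direction. The expected step is a 1.2-fold higher number from compound 2 to compound 4 (0.08 log units; within the scatter). For compound 4 the estimated value is 10000 nM, with an expected range of 4500 nM to 24000 nM.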

Compound 4, half-maximal cytotoxic concentration: 2300 nM
Compound 4: the middle estimate sits 4.3-fold (0.64 log units) above what was measured, outside the stated range (below it).
By their numbers in this assay, from the lowest: compound 4; then compounds 2, 1 and 3 (each within the scatter of the next, the first and the last beyond it).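

In this assay, 4-fluorophenyl in place of hydrogen on this carbon, two ring bonds from the ring sulfur, gives a 3.7-fold lower number from compound 2 to compound 4 (0.56 log units; beyond the scatter), so the number at this position can move beyond the scatter, towards higher toxicity in this test. Among these compounds, the only earlier step at a ring carbon, a 1.5-fold lower number from compound 1 to compound 2 (0.17 log units; within the scatter), concerned phenyl on another carbon and showed no such change. Nothing available explains the step. As far as these compounds go, it remains open whether unsubstituted phenyl at this carbon would give the same step, or whether the fluorine matters. A smaller group here, such as methyl or an amine, also remains untested in what is shown.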